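This account rests on a few compounds, and the source may have more. Where it says the series, first, only, none or still open, it means among the compounds named here.

Of the compounds shown here, three on a shared core have been measured in an assay on CHO cells for displacement of a labelled ligand from 5-hydroxytryptamine receptor 1B (Homo sapiens); on this read-out lower numbers stand for stronger inhibition and higher numbers for weaker inhibition. Compound 1, `O[C@H]1Cc2ccccc2C1NC1CCN(CCCc2c[nH]c3ccc(-n4cnnc4)cc23)CC1`, gives 300 nM in this assay. Compound 2, `c1ccc(C2CCCCN2C2CCN(CCCc3c[nH]c4ccc(-n5cnnc5)cc34)CC2)cc1`, gives 410 nM in this assay, and compound 3, `CC(=O)Nc1ccc([C@H](C)NCC2CCN(CCCc3c[nH]c4ccc(-n5cnnc5)cc34)CC2)cc1`, gives 9.3 nM in this assay. Among these three numbers compound 1 holds the second highest; compound 2 is nearest to it, with a value that lies within the scatter of repeated measurements, while compound 3 is furthest from it, with a number that is lower by a margin well beyond the scatter.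

Compound 4, `CN(Cc1ccsc1)C1CCN(CCCc2c[nH]c3ccc(-n4cnnc4)cc23)CC1`, has not yet been measured. It differs from compound 1 in one place: methyl((thiophen-3-yl)methyl)amino in place of (2-hydroxy-2,3-dihydro-1H-inden-1-yl)amino on a saturated ring carbon. Going by the values given here, no step between two measured compounds covers an exchange of this kind, so there is no direct precedent for how the number will move. What the measured compounds show is that compound 1 and compound 2 sit close together, whereas compound 3 stands clearly apart from both. With only this to rest on, the expected change is a 1.2-fold higher number from compound 1 to compound 4 (0.07 log units; within the scatter), a small step that is not expected to reach beyond the scatter. Compound 4 is therefore estimated at 350 nM in this assay, with a range from 90 nM to 1400 nM.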

Compound 4, half-maximal inhibitory concentration: 35 nM
For compound 4 the middle estimate is 10-fold (1.00 log units) above the measured one, outside the stated range (below it).
By their numbers in this assay, from the lowest: compound 3; then compound 4; then compounds 1 and 2 (each within the scatter of the next).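

In this assay, the group on the saturated ring carbon, three ring bonds from the ring nitrogen, can move the number by a margin beyond the scatter: methyl((thiophen-3-yl)methyl)amino in place of (2-hydroxy-2,3-dihydro-1H-inden-1-yl)amino gives an 8.6-fold lower number from compound 1 to compound 4 (0.93 log units; beyond the scatter). This single exchange alters several things at once: the entering group has fewer heavy atoms, 0 hydrogen-bond donors in place of 2, no defined stereocentre, and one five-membered aromatic ring with 1 hetero atom in place of a five-membered non-aromatic ring and a six-membered aromatic ring, so the step cannot be assigned to any one of these. No independent data bear on this result, and the reason for the step remains unexplained.

From the compounds shown here alone, it remains open which part of the entering group carries the step, a question that a hydrogen in place of the methyl on the amino nitrogen, or a phenyl ring in place of the thiophene, would address. Also open, going by these compounds, is whether the position of attachment on the thiophene matters, as a thiophen-2-yl or furan-3-yl group would show.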